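A few compounds are considered here, and "the series" means these few. Any claim that something is new, unique, unknown or untested is made for them only; others in the source may bear on it.

In a functional assay on OCI-Ly3 cells (Homo sapiens) for inhibition, read by CellTiter-Glo, with stated times of 48 h and 96 h (on this read-out higher numbers stand for weaker inhibition of growth and lower numbers for stronger inhibition of growth), compound 1 `CC(C)[C@@H](C(=O)N1CCC[C@H]1C(=O)N[C@@H](CCCNC(=N)N)C(=O)CF)N(C)C(=O)OCc1ccccc1` gives only a limit of the assay, > 20000 nM. Compound 2 `CC(C)[C@H](NC(=O)c1ccccc1Br)C(=O)N1CCC[C@H]1C(=O)N[C@@H](CCCNC(=N)N)C(=O)CF` gives 4240 nM. Compound 3 `CC(C)[C@H](NC(=O)c1ccc(Cl)cc1)C(=O)N1CCC[C@H]1C(=O)N[C@@H](CCCNC(=N)N)C(=O)CF` gives 1240 nM, the lowest number of the set, and so the strongest growth inhibition so far.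

Compound 4 `CC(C)[C@H](NC(=O)c1ccc(C#N)cc1)C(=O)N1CCC[C@H]1C(=O)N[C@@H](CCCNC(=N)N)C(=O)CF` differs from compound 3 in one small group: cyano in place of chloro on an aromatic carbon.

Among the compounds with values here, no measured step makes this exact swap. The closest evidence is a 3.4-fold lower number from compound 2 to compound 3 (0.53 log units; beyond the scatter), a modest change that shows the number can respond when the aromatic ring is altered. The larger steps, an at least 16-fold lower number from compound 1 to compound 3 (1.20 log units; beyond the scatter) and an at least 4.7-fold lower number from compound 1 to compound 2 (0.67 log units; beyond the scatter), replace a much bigger piece of the molecule, so they say little about a single group on the ring.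

A swap this small is therefore not expected to move the number beyond the scatter, though a slight rise is possible. The expected change is a 1.4-fold higher number from compound 3 to compound 4 (0.14 log units; within the scatter). For compound 4 the estimated value is 1700 nM, within an expected range of 650 nM to 4500 nM.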

Compound 4, concentration for 50% growth inhibition: 6660 nM
Beside the measured number, compound 4's estimate is 3.9-fold (0.59 log units) below it; measured number above the stated range.
By their numbers in this assay, from the lowest: compound 3; then compounds 2 and 4 (each within the scatter of the next). At a limit, above all of these: compound 1.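

In this assay, changing only the small group on the aromatic ring gives a 5.4-fold higher number from compound 3 to compound 4 (0.73 log units; beyond the scatter), so this place is sensitive, and cyano cannot stand in for chloro here even though the swap adds no ring and no net charge. The step of a 1.6-fold higher number from compound 2 to compound 4 (0.20 log units; within the scatter) stays within the scatter, so the gain seen with compound 3 does not come with every 4-substituted phenyl group. The step of an at least 3.0-fold lower number from compound 1 to compound 4 (0.47 log units; beyond the scatter) gives only a bound, since compound 1 sits at a limit: the limit of > 20000 nM in this assay, at which 1 of the 4 values shown sits.

Going by these compounds, whether fluoro, methyl or an amine on the same ring carbon would read like chloro or like cyano remains open. A single pair also cannot show what it is about chloro that this read-out responds to.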